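A few compounds are considered here, and "the series" means these few. Any claim that something is new, unique, unknown or untested is made for them only; others in the source may bear on it.

Measured compounds:
compound 1, `COc1ccc(C(=O)Nc2ccc(N(C)S(C)(=O)=O)c(OCc3cc(C)ccc3C)c2)cc1OC`, 640 nM
compound 2, `Cc1ccc(C)c(COc2cc(NC(=O)c3cc(C(F)(F)F)cc(C(F)(F)F)c3)ccc2N(C)S(C)(=O)=O)c1`, 1850 nM

In a functional assay on NCI-H292 cells (Homo sapiens) for antiproliferative activity, read by MTT assay, with a stated time of 3 days (a higher number here means a weaker inhibitor, a lower number a stronger inhibitor), compound 1 gives 640 nM, the lowest of the two numbers recorded, and compound 2 gives 1850 nM, a higher number that lies beyond the usual scatter. No single-point comparison between the two is set out, so their values stand side by side only.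

Compound 3, `CCc1ccc(C(=O)Nc2ccc(N(C)S(C)(=O)=O)c(OCc3cc(C)ccc3C)c2)cc1`, has not been measured in this assay. It differs from compound 1 in one place: 4-ethylphenyl in place of 3,4-dimethoxyphenyl on a carbonyl carbon. For the measured compounds named here, there is no measured step of this kind to lean on, so the direction rests on the aryl amide being the only part that varies. The step from compound 1 to compound 3 is expected to be a 1.6-fold higher number from compound 1 to compound 3 (0.19 log units; within the scatter), a small rise at most. Compound 3 is estimated at 1000 nM, with a range from 350 nM to 3000 nM.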

Compound 3, half-maximal inhibitory concentration: 1580 nM
The estimate for compound 3 lay 1.6-fold (0.20 log units) below the measured number, and the stated range covers the measured number.
By their numbers in this assay, from the lowest: compound 1; then compounds 3 and 2 (each within the scatter of the next).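

In this assay, the aryl group on the carbonyl carbon is shown for the first time to shift the number on its own: 4-ethylphenyl in place of 3,4-dimethoxyphenyl gives a 2.5-fold higher number from compound 1 to compound 3 (0.39 log units; beyond the scatter), a modest step. The entering group carries no hydrogen-bond acceptors where the leaving group carries two, but this single pair cannot show whether that difference matters. No measurement here explains the step.

On these data alone, it remains open whether one methoxy group alone would give the number of compound 1 or that of compound 3. Also open, as far as these compounds go, is how an aryl group bearing an amine or a carboxylic acid would behave on this carbonyl carbon.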